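From Anilino to (4-Methoxyphenyl)amino in Compound 2

A few compounds are considered here, and "the series" means these few. Any claim that something is new, unique, unknown or untested is made for them only; others in the source may bear on it.

Of the compounds shown here, three built on a shared core have been measured in a functional assay on L1210 cells (Mus musculus) for antiproliferative activity, read by cell counting, with a stated time of 2 days; on this read-out lower numbers stand for stronger inhibition and higher numbers for weaker inhibition. Compound 1 `COc1cccc(Nc2nc(N)c(C(=O)c3ccccc3)s2)c1` gives 8200 nM, compound 3 `COc1ccc(Nc2nc(N)c(C(=O)c3ccc(Br)cc3)s2)cc1` gives 110 nM, and compound 2 `COc1cc(C(=O)c2sc(Nc3ccccc3)nc2N)cc(OC)c1OC` gives 18 nM. Compound 2 thus holds the lowest number of the three, and its gaps to both others lie beyond the usual scatter.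

Compound 4 `COc1ccc(Nc2nc(N)c(C(=O)c3cc(OC)c(OC)c(OC)c3)s2)cc1` has not yet been measured. It departs from compound 2 by a single change methoxy in place of hydrogen on an aromatic carbon, para to a large group, which turns anilino into (4-methoxyphenyl)amino. For the measured compounds named here, no measured pair isolates this change. Compound 3 carries the same (4-methoxyphenyl)amino group and gives 110 nM, although it also differs from compound 4 elsewhere. A modest rise is therefore expected, with the estimated step of a 1.7-fold higher number from compound 2 to compound 4 (0.22 log units; within the scatter) lying close to the scatter. In this assay, compound 4 is estimated at 30 nM, with an expected range of 8 nM to 120 nM.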

Compound 4, half-maximal inhibitory concentration: 1500 nM
Compound 4: the middle estimate sits 50-fold (1.70 log units) below what was measured; the whole stated range lies below it.
By their numbers in this assay, from the lowest: compound 2; then compound 3; then compound 4; then compound 1.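

In this assay, for the compounds shown here, the step of an 83-fold higher number from compound 2 to compound 4 (1.92 log units; beyond the scatter) is the first reading that isolates this change, since compounds 1, 2 and 3 differ from one another in more than one place. It shows that this position is far from indifferent: with everything else held as in compound 2, methoxy in place of hydrogen on an aromatic carbon, para to a large group, costs much of the inhibition, a step well beyond the scatter. No measurement given here bears on why the number rises so steeply.

As far as these compounds go, it remains open whether this cost belongs to methoxy itself or would also come with fluorine, methyl or hydroxy at the same place. From the compounds shown here alone, it is also open whether the step would be as large with the bromine-bearing ring of compound 3 on the carbonyl.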